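The compounds below may be only part of what the source reports. "The series", "measured", "known", "first", "only" and "open" are said of these compounds alone.

Compound 1, `Cc1[nH]n(-c2nc3ccccc3[nH]2)c(=O)c1CC(=O)O`: 15000 nM
Compound 2, `Cc1[nH]n(-c2nc3ccccc3[nH]2)c(=O)c1Cc1ccc(Cl)cc1`: > 10000 nM

In an assay on isolated protein for inhibition of alpha-ketoglutarate-dependent dioxygenase alkB homolog 3 (Homo sapiens), read by polymerase chain reaction, with a stated time of 1 h (on this read-out lower numbers stand for stronger inhibition and higher numbers for weaker inhibition), compound 1 gives 15000 nM. For compound 2 this assay reports only a limit, > 10000 nM, so compound 2 stands at the edge of what was measured rather than at a number. The step from compound 1 to compound 2 reads a step that the limit leaves unreadable from compound 1 to compound 2 because of the limit of > 10000 nM in this assay, at which 1 of the 2 values shown sits. Compound 3, `Cc1[nH]n(-c2nc3ccccc3[nH]2)c(=O)c1Cc1ccc(Cl)cc1Cl`, differs from compound 2 by chloro in place of hydrogen on an aromatic carbon. For the measured compounds named here, no measured step in this assay concerns a chloro entering in place of hydrogen, so none bears directly on this change, and the one measured step, from carboxy to 4-chlorophenyl, is unreadable. With compound 2 known only as a limit, compound 3 is expected to stay weak as well, a step that the limit leaves unreadable from compound 2 to compound 3. Compound 3 is estimated at 20000 nM, within 8000 nM to 60000 nM, with a fair chance that this assay again reports only a limit.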

Compound 3, half-maximal inhibitory concentration: > 10000 nM
Compound 3: only a limit was reported; the forecaster's own chance of this, stated with the estimate: 70%; the middle value is on the limit's open side.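

No new step can be read from compound 3 to compound 2 or compound 1, because compound 2 and compound 3 are known only as limits in this assay: the limit of > 10000 nM in this assay, at which 2 of the 3 values shown sit.

The compounds shown leave open whether chloro in place of hydrogen changes inhibition at all, and how compound 2 and compound 3 truly compare with compound 1.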